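The compounds below may be only part of what the source reports. "The series", "measured", "known", "first", "only" and "open" are said of these compounds alone.

Three compounds have been measured in a functional assay on HepG2 cells (Homo sapiens) for cytotoxicity, read by MTT assay, with a stated time of 72 h; on this read-out lower numbers stand for stronger inhibition and higher numbers for weaker inhibition:

Compound 1 `COc1ccc2ccc(=O)oc2c1C(/C=C/c1ccc(C(F)(F)F)cc1)=N/NC(N)=O`: 96 nM
Compound 2 `COc1ccc2ccc(=O)oc2c1C(/C=C/c1ccc(C)cc1)=N/NC(N)=O`: 93 nM
Compound 3 `COc1ccc2ccc(=O)oc2c1C1=NN(c2ccccc2)C(c2ccccc2)C1`: 73 nM

Among these three numbers, compound 2 differs from compound 1 and from compound 3 by less than the usual scatter of this assay, so the three results cannot be told apart with confidence.

Compound 4 `COc1ccc2ccc(=O)oc2c1C(/C=C/c1ccccc1)=N/NC(N)=O` has not yet been measured. It differs from compound 2 by hydrogen in place of methyl on an aromatic carbon. Within the data shown here, one measured step bears on this change: a 1.0-fold lower number from compound 1 to compound 2 (0.01 log units; within the scatter), a swap at the same aromatic carbon that left the number essentially unchanged. Compound 3, with a different arrangement around the shared core, gives a number close to compound 2 as well, but it shares no single-point change with compound 4 and adds nothing directly. Among the measured compounds shown here, since the one relevant step shows no effect beyond the scatter, the expectation for compound 4 is no step beyond the scatter either, in neither direction.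

Compound 4 is therefore estimated to give 95 nM in this assay, with a range from 50 nM to 190 nM. The expected step is a 1.0-fold higher number from compound 2 to compound 4 (0.01 log units; within the scatter).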

Compound 4, half-maximal inhibitory concentration: 82 nM
Compound 4: the middle estimate sits 1.2-fold (0.06 log units) above what was measured, within the range that was stated.
By their numbers in this assay, from the lowest: compounds 3, 4, 2 and 1 (each within the scatter of the next).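

With compound 4, the aromatic carbon para to a large group now carries three different substituents across the series in this assay: hydrogen, methyl and trifluoromethyl. Hydrogen in place of methyl gives a 1.1-fold lower number from compound 2 to compound 4 (0.05 log units; within the scatter) and hydrogen in place of trifluoromethyl gives a 1.2-fold lower number from compound 1 to compound 4 (0.07 log units; within the scatter) and, since both steps lie within the scatter, neither group is needed at this carbon to keep the number where it stands. Nothing measured here says why these swaps leave the number unchanged.

On these data alone, whether a carboxylic acid, an amine or a methoxy group at this carbon would also leave the number unchanged remains open. Also open, as far as these compounds go, is whether the same swaps would matter on the different arrangement around the shared core seen in compound 3.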